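Benzyl for methylsulfonyl on the ring nitrogen: an estimate

The source may hold more compounds than are shown below. What is called first, only, known or untested is meant among the compounds shown, and "the series" means these compounds.

Compound 2 `Cc1ccc(-c2c(C)c(-c3ccc(C)c(C)c3)c(C(OC(C)(C)C)C(=O)O)c(C)c2NS(C)(=O)=O)cc1C` gives 15000 nM in an ADME assay on MT4 cells (Homo sapiens) for cytotoxicity, read by MTT assay, with a stated time of 4 days; on this read-out higher numbers stand for lower toxicity in this test and lower numbers for higher toxicity in this test. Among the measured compounds this is the lowest number. Compound 3 `Cc1ccc(-c2c(C)c(-c3ccc(Cl)cc3)c(C(OC(C)(C)C)C(=O)O)c(C)c2NS(C)(=O)=O)cc1C` gives 26000 nM in this assay, and the gap between these two is a 1.7-fold higher number from compound 2 to compound 3 (0.24 log units; within the scatter). Compound 1 `Cc1ccc(-c2c(C)c(-c3ccc4c(c3)CCO4)c(C(OC(C)(C)C)C(=O)O)c(C)c2NS(C)(=O)=O)cc1C` gives 38000 nM in this assay; the step down to the lowest value is a 2.5-fold lower number from compound 1 to compound 2 (0.40 log units; beyond the scatter), while the remaining measured step is a 1.5-fold lower number from compound 1 to compound 3 (0.16 log units; within the scatter).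

Compound 4 `Cc1ccc(-c2c(C)c(-c3ccc(C)c(C)c3)c(C(OC(C)(C)C)C(=O)O)c(C)c2NCc2ccccc2)cc1C` differs from compound 2 by benzyl in place of methylsulfonyl on a nitrogen on an aromatic ring. Every measured step varies the aryl group on the far side of the shared core and leaves the methanesulfonamido nitrogen untouched, so none of them speaks directly to this change. What the measured steps do show is that the whole set sits close together: only one of them lies beyond the scatter, and that one is described as modest. For the measured compounds named here, with no comparable step to draw on, compound 4 is expected to stay near its parent in this assay, the expected change being no change at the digits printed from compound 2 to compound 4 (within the scatter), with wide uncertainty in either direction. Compound 4 is therefore estimated at 15000 nM, within a range from 5000 nM to 45000 nM.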

Compound 4, half-maximal cytotoxic concentration: 4000 nM
For compound 4 the middle estimate is 3.8-fold (0.57 log units) above the measured one; measured number outside the range, below it.
By their numbers in this assay, from the lowest: compound 4; then compounds 2, 3 and 1 (each within the scatter of the next, the first and the last beyond it).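

Placing benzyl instead of methylsulfonyl on the nitrogen on the aromatic ring gives a 3.8-fold lower number from compound 2 to compound 4 (0.57 log units; beyond the scatter) in this assay, so this nitrogen, held constant across compounds 1, 2 and 3, proves able to move the number beyond the scatter. The change swaps a group with two hydrogen-bond acceptors and two double bonds outside aromatic rings for one with a six-membered aromatic ring and no acceptors, so several features change at once and this single step cannot separate them. Nothing available explains why the number falls with this change.

From the compounds shown here alone, it remains open whether the step follows from the arrival of the aromatic ring of benzyl or from the departure of methylsulfonyl, and how a methyl, an acetyl or a free amine on this nitrogen would read. For the compounds shown here, the change is also seen only with 3,4-dimethylphenyl on the far side of the shared core, and whether it would hold with 4-chlorophenyl or with the oxygen-containing ring system of compound 1 remains unanswered.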